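The source may report more compounds than this note shows. Statements on the series, on what has been measured and on what is new or still open speak of the compounds shown alone.

Measured compounds:
- compound 1, `N#C/C(=C\c1c(-c2ccccc2)[nH]c2ccccc12)C(=O)N1CCCCC1`, in a functional assay on MT4 cells (Homo sapiens) for antiproliferative activity, read by MTT assay, with a stated time of 96 h (a lower number here means that less compound is needed, a higher number that more compound is needed for the effect), compound 1 gives 9600 nM
- compound 2, `N#C/C(=C\c1c(-c2ccccc2)[nH]c2ccccc12)C(N)=O`, in this assay compound 2 gives 6000 nM

Both compounds share one core and differ only in the group on the carbonyl carbon. Compound 2 stands at the lower of the two numbers, but the step of a 1.6-fold lower number from compound 1 to compound 2 (0.20 log units; within the scatter) is too small to rank the two compounds against each other.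

Compound 3, `N#C/C(=C\c1c(-c2ccccc2)[nH]c2ccccc12)C(=O)c1cccs1`, is the next variation at the same carbonyl carbon: thiophen-2-yl in place of amino on a carbonyl carbon. Here the change is no longer a swap of one amide substituent for another, as in the step from compound 1 to compound 2, but an exchange of the carbamoyl group for a (thiophen-2-yl)carbonyl group. Within the data shown here, the only measured step at this position, the one from compound 1 to compound 2, was small, so it gives a direction of neither gain nor loss for the new group; it bears on the expectation only by showing that this part of the molecule tolerates change without a large shift. Compound 3 is therefore expected to land close to compound 2, with a step of a 1.2-fold lower number from compound 2 to compound 3 (0.08 log units; within the scatter), and its estimated value in this assay is 5000 nM, within a range from 1200 nM to 20000 nM.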

Compound 3, half-maximal effective concentration: 400 nM
Compound 3: middle estimate off by 13-fold (1.10 log units), on the high side, and the stated range ends above it.
By their numbers in this assay, from the lowest: compound 3; then compounds 2 and 1 (each within the scatter of the next).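

In this assay, the carbonyl carbon is not a place where any change makes little difference: thiophen-2-yl in place of amino gives a 15-fold lower number from compound 2 to compound 3 (1.18 log units; beyond the scatter), and thiophen-2-yl in place of piperidin-1-yl gives a 24-fold lower number from compound 1 to compound 3 (1.38 log units; beyond the scatter). The earlier exchange of one nitrogen-linked group for another had shown no readable shift, so its small step said nothing about a group joined to the carbonyl carbon through a ring carbon, and among these three compounds only the change from an amide to the (thiophen-2-yl)carbonyl group moves the number beyond the scatter. Among these compounds, nothing at hand explains why this exchange lowers the number so far.

With a single group of this new kind, the compounds shown cannot tell whether the lower number belongs to the sulfur, to the five-membered aromatic ring, or simply to the loss of the amide nitrogen. A phenyl group, a furan-2-yl group or a plain methyl group on the same carbonyl carbon would help separate these readings.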